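Swapping Chloro for Nitro: Little Change Expected

The source may report more compounds than this note shows. Statements on the series, on what has been measured and on what is new or still open speak of the compounds shown alone.

Of the compounds shown here, three have been tested in a functional assay on HepG2 cells (Homo sapiens) for inhibition, read by sulforhodamine B assay, with a stated time of 72 h; on this read-out lower numbers stand for stronger inhibition and higher numbers for weaker inhibition. Compound 1 `Cc1ccc(C2=Nn3c(nnc3C(C)c3ccc(CC(C)C)cc3)SC2)cc1` gives 7300 nM, compound 3 `CC(C)Cc1ccc(C(C)c2nnc3n2N=C(c2ccc(Br)cc2)CS3)cc1` gives 6400 nM, and compound 2 `CC(c1ccc(-c2ccccc2)c(F)c1)c1nnc2n1N=C(c1ccc(Cl)cc1)CS2` gives 6700 nM. On the bare digits compound 2 holds the second highest of the three numbers, yet its gaps to compound 3 and to compound 1 both lie within the usual scatter, so the three compounds cannot be ranked against one another. For the measured compounds named here, the only one-place step among them, a 1.1-fold lower number from compound 1 to compound 3 (0.06 log units; within the scatter), also stayed within the scatter.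

Compound 4 `CC(c1ccc(-c2ccccc2)c(F)c1)c1nnc2n1N=C(c1ccc([N+](=O)[O-])cc1)CS2` has not yet been measured in this assay. It differs from compound 2 by nitro in place of chloro on an aromatic carbon. Going by the values given here, no measured step exchanges these two particular groups; the one step that also changes a group on an aromatic carbon, a 1.1-fold lower number from compound 1 to compound 3 (0.06 log units; within the scatter), produced no shift worth noting. There is therefore no basis for expecting a step beyond the scatter in this assay. Compound 4 is expected to give about 6500 nM, with a likely range from 2500 nM to 17000 nM. The estimated step is a 1.0-fold lower number from compound 2 to compound 4 (0.01 log units; within the scatter).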

Compound 4, half-maximal inhibitory concentration: 4300 nM
Compound 4: middle estimate off by 1.5-fold (0.18 log units), on the high side, within the range that was stated.
By their numbers in this assay, from the lowest: compounds 4, 3, 2 and 1 (each within the scatter of the next).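

Replacing one chlorine with the three heavy atoms of a nitro group, which brings two hydrogen-bond acceptors, leaves the result in this assay within the scatter (a 1.6-fold lower number from compound 2 to compound 4 (0.19 log units; within the scatter)). The 4-chlorophenyl to 4-nitrophenyl exchange is thus a second change on an aromatic carbon that shows no clear effect, alongside the bromo-for-methyl step (a 1.1-fold lower number from compound 1 to compound 3 (0.06 log units; within the scatter)), although that step was made on a different remainder of the molecule. No supporting data bear on why this step has the size it has.

From the compounds shown here alone, whether this position would respond to an amine, a carboxylic acid or a longer chain remains open. Also open, going by these compounds, is whether the nitro group would behave in the same way on the remainder of the molecule found in compound 3.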